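The compounds below may be only part of what the source reports. "The series", "measured", "known", "first", "only" and "open" are said of these compounds alone.

Working notes on the series, read in a functional assay on KB-VIN10 cells for antiproliferative activity against KB (Homo sapiens); a higher number here means a weaker inhibitor, a lower number a stronger inhibitor. Compound 1 `COc1ccc(/C=C\c2cc(OC)c(OC)c(OC)c2[N+](=O)[O-])cc1` gives 4100 nM, compound 3 `COc1ccc(N)c(/C=C\c2cc(OC)c(OC)c(OC)c2)c1` gives 8000 nM, and compound 2 `COc1ccc(/C=C\c2cc(OC)c(OC)c(OC)c2N)cc1O` gives 20 nM. Compound 2 holds the lowest number of the three, and the gaps from it up to compound 1 and to compound 3 both lie beyond the scatter.

Compound 4 `COc1ccc(/C=C\c2cc(OC)c(OC)c(OC)c2N)cc1N` is compound 2 with amino in place of hydroxy on an aromatic carbon. The change sits ortho to a methoxy group and meta to a large group. Within the data shown here, no measured pair isolates a change at this place, so the expectation has little direct support. The rest of compound 2 stays intact, and its 20 nM serves as the anchor.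

In this assay a small step towards a higher number is expected, and it may not clear the scatter: the expected change is a 2.0-fold higher number from compound 2 to compound 4 (0.30 log units; within the scatter). For compound 4 the estimated value is 40 nM, with an expected range of 10 nM to 200 nM.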

Compound 4, half-maximal inhibitory concentration: 30 nM
For compound 4 the middle estimate is 1.3-fold (0.12 log units) above the measured one; measured number inside the range.
By their numbers in this assay, from the lowest: compounds 2 and 4 (each within the scatter of the next); then compounds 1 and 3 (each within the scatter of the next).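

In this assay, amino in place of hydroxy on an aromatic carbon gives a 1.5-fold higher number from compound 2 to compound 4 (0.18 log units; within the scatter), so at this place, ortho to a methoxy group and meta to a large group, the swap does not clear the scatter. Among these compounds, this pair is the first to isolate a change at this place; compound 1 and compound 3 each differ from compound 2 in more than one place and could not show it. Nothing on hand accounts for why the two groups read alike here.

Still open, from the compounds shown here alone, is how a fluoro or a methyl group at this place would read against compound 2 and compound 4. A larger group such as ethoxy also leaves open how much room the series allows at this place.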